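Metabolic stability along the path from compound 2 to compound 4

The source may report more compounds than this note shows. Statements on the series, on what has been measured and on what is new or still open speak of the compounds shown alone.

Of the compounds shown here, three have been measured in an ADME assay on microsomes from liver (Mus musculus) for metabolic stability, read by LC-MS, with a stated time of 10 min, tested at 0.5 uM; a lower number here means that less of the compound is left, a higher number that more of the compound is left. Compound 1 `c1ccc2c(c1)CN[C@@H](CN(CC[C@H]1CCCNC1)[C@H]1CCCc3cccnc31)C2` gives 56% in this assay, compound 2 `c1cnc2c(c1)CCC[C@@H]2N(CCCN1CCNCC1)Cc1nc2ccccc2[nH]1` gives 68%, and compound 3 `c1ccc2c(c1)CN[C@@H](CN(CCC1CCNCC1)[C@H]1CCCc3cccnc31)C2` gives 32%. Compound 2 stands highest of the three; its nearest neighbour on the numbers is compound 1, and the furthest is compound 3, both gaps being beyond the scatter. Going by the values given here, the one step between measured compounds that differ in a single place is a number 24 percentage points lower from compound 1 to compound 3 (beyond the scatter), a modest drop that concerns only the position of the piperidine ring on the chain.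

Compound 4 `c1cnc2c(c1)CN[C@@H](CN(CCCN1CCNCC1)[C@H]1CCCc3cccnc31)C2` has not yet been measured in this assay. It differs from compound 2 in the following way: a group of 10 heavy atoms (8 carbon, 2 nitrogen; one six-membered non-aromatic ring with 1 hetero atom, one six-membered aromatic ring with 1 hetero atom) in place of a group of 9 heavy atoms (7 carbon, 2 nitrogen; one five-membered aromatic ring with 2 hetero atoms, one six-membered aromatic ring of carbon only), on a saturated chain carbon bound to an amine nitrogen. No measured step concerns this exchange, so the size of the change it brings cannot be read from the other pairs. The closest point of reference is compound 1, whose saturated bicyclic group attached to the amine nitrogen resembles the entering group and which gives 56%. On that footing a step of a number 13 percentage points lower from compound 2 to compound 4 (beyond the scatter) is expected, downward but of uncertain size. Compound 4 is therefore estimated at 55%, with a range from 35% to 75%.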

Compound 4, percent of the compound remaining: 78%
Estimate against measurement, compound 4: 23 percentage points below; the whole stated range lies below it.
By their numbers in this assay, from the lowest: compound 3; then compound 1; then compounds 2 and 4 (each within the scatter of the next).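

In this assay, the exchange of 1H-benzimidazol-2-yl for the entering group, on a saturated chain carbon bound to an amine nitrogen, amounts to a number 10 percentage points higher from compound 2 to compound 4 (within the scatter) and so leaves the two compounds indistinguishable in this read-out. Going by these compounds alone, this is the first view of this place, since the only earlier step concerned whether a piperidine was attached through its 3- or 4-position, and it shows that this place can take a substantial change of group without a step beyond the scatter: a five-membered aromatic ring and a carbon-only aromatic ring leave, while a six-membered non-aromatic ring and a six-membered aromatic ring, each with one hetero atom, enter along with a defined stereocentre. No measurement among the data given bears on why the two groups read alike.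

Going by these compounds, whether a smaller group on that carbon, such as a plain phenyl or a 2-pyridyl, would also stay within the scatter of compound 2 remains open. It is equally open whether the same exchange would read alike in a compound carrying piperidin-3-yl or piperidin-4-yl on the chain, where this assay has already shown a step beyond the scatter.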